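A few compounds are considered here, and "the series" means these few. Any claim that something is new, unique, unknown or untested is made for them only; others in the source may bear on it.

Measured compounds:

Compound 1 `COc1ccc(/C=C\C(=O)O)c(OCc2cn(-c3ccc(NC(C)=O)cc3)nn2)c1CC=C(C)C` gives 22600 nM in a functional assay on COLO 205 cells (Homo sapiens) for cytotoxicity, read by MTT assay, with a stated time of 24 h; a higher number here means a weaker inhibitor, a lower number a stronger inhibitor.
Compound 2 `COc1ccc(/C=C\C(=O)O)c(OCc2cn(-c3ccc(NC(=O)c4ccccc4)cc3)nn2)c1CC=C(C)C` gives 20300 nM in this assay.
Compound 3 `COc1ccc(/C=C\C(=O)O)c(OCc2cn(-c3cccc(C#N)c3)nn2)c1CC=C(C)C` gives 26800 nM in this assay.

Compound 3 carries the highest of the three numbers, yet it is not separated from the others: the move from compound 1 is small (a 1.2-fold higher number from compound 1 to compound 3 (0.07 log units; within the scatter)), and the value of compound 2 sits within the scatter of that of compound 3 as well. The three compounds are thus indistinguishable in this assay on the present evidence.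

Compound 4 `COc1ccc(/C=C\C(=O)O)c(OCc2cn(-c3ccccc3)nn2)c1CC=C(C)C` is the next step from compound 3: hydrogen in place of cyano on an aromatic carbon. Neither measured step touches this spot. The step from compound 1 to compound 2 changes a group on the carbonyl carbon (a 1.1-fold lower number from compound 1 to compound 2 (0.05 log units; within the scatter)), and the step from compound 1 to compound 3 swaps the whole aryl substituent on the aromatic nitrogen (a 1.2-fold higher number from compound 1 to compound 3 (0.07 log units; within the scatter)); both stay within the scatter. Since a larger swap on the same aryl ring left the number unchanged, removal of the cyano is expected to give no step beyond the scatter in this assay, in either direction. The expected step is a 1.1-fold lower number from compound 3 to compound 4 (0.03 log units; within the scatter). Compound 4 is therefore estimated at 25000 nM, with a range from 12000 nM to 52000 nM.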

Compound 4, half-maximal inhibitory concentration: 32300 nM
For compound 4 the middle estimate is 1.3-fold (0.11 log units) below the measured one, within the range that was stated.
By their numbers in this assay, from the lowest: compounds 2, 1, 3 and 4 (each within the scatter of the next).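

Compound 4 is the only compound shown with no substituent on the aryl ring carried by the aromatic nitrogen, and in this assay replacing the cyano with hydrogen gives a 1.2-fold higher number from compound 3 to compound 4 (0.08 log units; within the scatter), so the nitrile is not required at this place for a number of this size. Going by these compounds alone, compound 4 also gives the first direct comparison of the two amide-bearing compounds with the plain phenyl: hydrogen in place of acetamido gives a 1.4-fold higher number from compound 1 to compound 4 (0.16 log units; within the scatter) and hydrogen in place of benzamido gives a 1.6-fold higher number from compound 2 to compound 4 (0.20 log units; within the scatter), so neither of these groups nor the cyano can be told from hydrogen on this ring on the present evidence. No measurement is available to explain why these changes leave the number within the scatter.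

The compounds shown leave open whether any group on this ring can move the number beyond the scatter, as an amine or a hydroxyl group at the place of the cyano might or might not do. They also leave open how far the number depends on the rest of the shared core, which is the same in all four compounds.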